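Methoxy position on the benzoyl group of compound 1

The compounds below may be only part of what the source reports. "The series", "measured", "known", "first", "only" and "open" are said of these compounds alone.

Measured so far in a functional assay on CCRF-CEM cells (Homo sapiens) for antiproliferative activity, read by cell counting, with a stated time of 2 days; on this read-out higher numbers stand for weaker inhibition and lower numbers for stronger inhibition:
- compound 1, `COc1ccc(Nc2nc(N)c(C(=O)c3ccccc3OC)s2)cc1`: 17 nM
- compound 2, `COc1ccccc1C(=O)c1sc(Nc2ccccc2)nc1N`: 730 nM

Compound 1 gives the lowest of the two numbers in this assay; compound 2 stands nearest, a 43-fold higher number from compound 1 to compound 2 (1.63 log units; beyond the scatter). That single step, hydrogen in place of methoxy on an aromatic carbon, concerns the aniline side of the shared core and is large.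

Compound 3, `COc1ccc(Nc2nc(N)c(C(=O)c3cccc(OC)c3)s2)cc1`, has the same atoms as compound 1, joined differently: 3-methoxyphenyl in place of 2-methoxyphenyl on a carbonyl carbon. Among the compounds with values here, no measured step touches the group on the carbonyl carbon, so the step from compound 1 to compound 2 gives no direct guide here. With nothing shown against it, a change at most modest is expected for compound 3, with a weakening more likely than the reverse, which as a step from compound 1 would be a 2.6-fold higher number from compound 1 to compound 3 (0.42 log units; beyond the scatter). Compound 3 is therefore estimated at 45 nM, within 10 nM to 250 nM.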

Compound 3, half-maximal inhibitory concentration: 9.9 nM
Beside the measured number, compound 3's estimate is 4.5-fold (0.66 log units) above it; the whole stated range lies above it.
By their numbers in this assay, from the lowest: compounds 3 and 1 (each within the scatter of the next); then compound 2.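

Placing the methoxy group differently on the ring at the carbonyl carbon, 3-methoxyphenyl in place of 2-methoxyphenyl, gives a 1.7-fold lower number from compound 1 to compound 3 (0.23 log units; within the scatter) in this assay, so the two placements cannot be told apart on this read-out. Within the data shown here, this is the first reading at this position, and it shows that this change keeps the number in the range of compound 1, whereas the change on the aniline side gives a 43-fold higher number from compound 1 to compound 2 (1.63 log units; beyond the scatter). Nothing at hand bears on why the two placements read alike.

Open, from the compounds shown here alone, is how the ring at the carbonyl carbon responds to a different group, such as a hydroxyl, a fluorine or an amine, or to plain hydrogen in place of methoxy. Also open, going by these compounds, is whether the two placements still read alike with hydrogen in place of methoxy on the aniline side.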